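Hydrogen in place of methyl on a saturated chain

The compounds below may be only part of what the source reports. "The series", "measured", "known", "first", "only" and "open" are said of these compounds alone.

- compound 1 `CCCCCCCCCCCCC(=O)OCCc1ccc(O)c(O)c1` gives 13200 nM
- compound 2 `CCCCCCCC(=O)OCCc1ccc(O)cc1` gives 133000 nM

Both values come from a toxicity assay on MRC5 cells (Homo sapiens) for inhibition, read by MTT assay, with a stated time of 72 h; on this read-out lower numbers stand for stronger inhibition and higher numbers for weaker inhibition. Of the two measured compounds, compound 1 holds the lower number, and its gap to compound 2 lies beyond the scatter. Compound 1, at 13200 nM, is therefore the lower of the two values available and the starting point for what follows.

The next compound to be measured is compound 3 `CCCCCCCCCCCC(=O)OCCc1ccc(O)c(O)c1`. It departs from compound 1 by one change, hydrogen in place of methyl on a saturated chain carbon, ten or more bonds along the chain from a carbonyl carbon. For the measured compounds named here, no step between measured compounds is available to size this change, so the expectation rests on the single small structural difference alone. In this assay, no step beyond the scatter is expected, with any small drift expected toward a higher number. An estimated 1.1-fold higher number from compound 1 to compound 3 (0.06 log units; within the scatter) would stay within the scatter. Compound 3 is expected at 15000 nM, with an estimated range of 7500 nM to 30000 nM.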

Compound 3, half-maximal inhibitory concentration: 38100 nM
Estimate against measurement, compound 3: 2.5-fold (0.40 log units) below; the whole stated range lies below it.
By their numbers in this assay, from the lowest: compound 1; then compound 3; then compound 2.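

In this assay, shortening the saturated chain by this single carbon is not a silent change: hydrogen in place of methyl, on a saturated chain carbon, gives a 2.9-fold higher number from compound 1 to compound 3 (0.46 log units; beyond the scatter) and so moves the result toward weaker inhibition. For the compounds shown here, this is the first step that can be sized, and although modest, it shows that the read-out registers a change this far along the chain from the carbonyl carbon, something the two earlier values could not show. Nothing measured here accounts for the step, so the result stands as an observation without an assigned cause.

A single step cannot show whether the number would keep dropping with a longer chain or level off, or whether it would rise steadily as the chain is cut further from methyl to hydrogen. As far as these compounds go, it also remains open how the assay would respond to a chain ending in a carboxylic acid or an amine in place of the terminal methyl on the core of compound 1.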